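A few compounds are considered here, and "the series" means these few. Any claim that something is new, unique, unknown or untested is made for them only; others in the source may bear on it.

Measured compounds:
Compound 1, `COc1ccccc1/C=c1/[nH]c(=O)/c(=C\c2cccc(Cl)c2Cl)[nH]c1=O`: "not active" (no number reported)
Compound 2, `C=CCn1c(=O)/c(=C\c2cccc(Cl)c2Cl)[nH]c(=O)/c1=C\c1ccccc1OC`: 900 nM

In a functional assay on K562 cells (Homo sapiens) for cytotoxicity, read by CCK-8 assay, with a stated time of 72 h (on this read-out lower numbers stand for stronger inhibition and higher numbers for weaker inhibition), compound 1 was recorded as "not active" (no number reported), with no number given. Going by the values given here, compound 2 is therefore the only member of the pair with a numerical result in this assay, where compound 2 gives 900 nM; it stands alone on the scale, with nothing measured to rank it against.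

Compound 3, `C=CCn1c(=O)/c(=C\c2cccc(C)c2)[nH]c(=O)/c1=C\c1ccccc1OC`, is the next compound, not yet tested in this assay. It differs from compound 2 in one place: 3-methylphenyl in place of 2,3-dichlorophenyl on a double-bonded chain carbon bound to an aromatic carbon. Among the compounds with values here, with no step between two measured compounds, there is no precedent to lean on for the size of such a change. The expectation is a modest step, probably toward weaker inhibition, but possibly no more than the ordinary scatter; the step from compound 2 to compound 3 is estimated at a 1.7-fold higher number from compound 2 to compound 3 (0.22 log units; within the scatter). For compound 3 the expected half-maximal inhibitory concentration in this assay is estimated at 1500 nM, with a range from 500 nM to 6000 nM.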

Compound 3, half-maximal inhibitory concentration: 8800 nM
For compound 3 the middle estimate is 5.9-fold (0.77 log units) below the measured one, outside the stated range (above it).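

In this assay, the series now has its first step between two measured compounds: 3-methylphenyl in place of 2,3-dichlorophenyl on a double-bonded chain carbon bound to an aromatic carbon gives a 9.8-fold higher number from compound 2 to compound 3 (0.99 log units; beyond the scatter), which shows that the read-out is sensitive to what this position carries, since the step means weaker inhibition. The exchange is also a small one by count, with 8 heavy atoms leaving and 7 entering and an aromatic carbon ring on both sides, yet compound 3 still gives a number and is not recorded as inactive, so this change weakens the result without abolishing it. No information is available here that would tie this step to any property of either group.

Going by these compounds alone, the single pair leaves open whether the step goes with losing the chlorine atoms or with gaining the methyl group, and whether it would be the same on the core of compound 1. It also leaves open how the number would respond to an amine, a carboxylic acid or a longer chain on that aromatic ring.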